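Amide-end variation on the spirohydantoin cholesterol-transporter series

The source may hold more compounds than are shown below. What is called first, only, known or untested is meant among the compounds shown, and "the series" means these compounds.

Measured compounds:
compound 1 `O=C(CN1CN(c2ccccc2)C2(CCN(C(=O)c3ccc(C4CCCCC4)cc3)CC2)C1=O)NCCO`, 2000 nM in an assay on HEK293 cells for displacement of a labelled ligand from NPC1-like intracellular cholesterol transporter 1 (Homo sapiens); on this read-out higher numbers stand for weaker inhibition and lower numbers for stronger inhibition
compound 2 `CC(C)(C)OC(=O)NCNC(=O)CN1CN(c2ccccc2)C2(CCN(C(=O)c3ccc(C4CCCCC4)cc3)CC2)C1=O`, 1700 nM
compound 3 `O=C(CN1CN(c2ccccc2)C2(CCN(C(=O)c3ccc(C4CCCCC4)cc3)CC2)C1=O)N1CCCCC1`, 1100 nM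

The three compounds share one core and differ only in the group on the carbonyl carbon of the side-chain amide. Compound 3 carries the lowest of the three numbers, yet its gap to compound 2, a 1.5-fold lower number from compound 2 to compound 3 (0.19 log units; within the scatter), and its gap to compound 1, a 1.8-fold lower number from compound 1 to compound 3 (0.26 log units; within the scatter), both fall within the scatter, so no ordering among the three can be claimed. The step from compound 1 to compound 2, a 1.2-fold lower number from compound 1 to compound 2 (0.07 log units; within the scatter), is likewise flat.

Compound 4 `CCC1CCCN(C(=O)CN2CN(c3ccccc3)C3(CCN(C(=O)c4ccc(C5CCCCC5)cc4)CC3)C2=O)C1` keeps the piperidin-1-yl amide of compound 3 and adds one group: ethyl in place of hydrogen on a saturated ring carbon. All measured steps touch this amide end of the molecule, and none moved the number beyond the scatter. Within the data shown here, no measured step adds a substituent to the piperidine ring itself, so the only guide is that this region has so far tolerated change without effect. Compound 4 is therefore expected to land close to compound 3, with a step of a 1.2-fold lower number from compound 3 to compound 4 (0.09 log units; within the scatter), and an estimated value of 900 nM, ranging from 400 nM to 2000 nM.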

Compound 4, half-maximal inhibitory concentration: 2600 nM
Beside the measured number, compound 4's estimate is 2.9-fold (0.46 log units) below it, and the stated range ends below it.
By their numbers in this assay, from the lowest: compounds 3, 2, 1 and 4 (each within the scatter of the next, the first and the last beyond it).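

In this assay, ethyl on a saturated ring carbon, two ring bonds from the ring nitrogen, gives the only step shown beyond the scatter, a 2.4-fold higher number from compound 3 to compound 4 (0.37 log units; beyond the scatter), so this amide end does respond to at least one change. The other two steps, a 1.5-fold higher number from compound 2 to compound 4 (0.18 log units; within the scatter) and a 1.3-fold higher number from compound 1 to compound 4 (0.11 log units; within the scatter), stay within the scatter, so among the amide groups only the unsubstituted piperidin-1-yl of compound 3 stands apart from 3-ethylpiperidin-1-yl. Nothing at hand bears on the cause of the step from hydrogen to ethyl.

Going by these compounds, whether the shift is specific to ethyl remains open, and methyl or a longer chain at the same ring carbon would bear on that. An amine or a carboxylic acid at this ring carbon also remains an open case.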